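Swapping an Ester for a Ketone on a Shared Core

The source may hold more compounds than are shown below. What is called first, only, known or untested is meant among the compounds shown, and "the series" means these compounds.

Of the compounds shown here, two have so far been tested in an assay on isolated protein with adenosine receptor A1 (Homo sapiens) as the target, read by ERK phosphorylation; a higher number here means a more potent compound, by a factor of ten per unit of this negative logarithm, a lower number a less potent compound. Compound 1 `Nc1scc(-c2cc(C(F)(F)F)cc(C(F)(F)F)c2)c1C(=O)c1ccc(Cl)cc1` gives 5.46, while compound 2 `CCOC(=O)c1c(N)sc2c1CCN(C(=O)OC(C)(C)C)CC2` gives 6.07, the higher of the two numbers, and the gap between them is beyond the usual scatter. Compound 3 `CC(C)(C)OC(=O)N1CCc2sc(N)c(C(=O)c3ccc(Cl)cc3)c2CC1` has not yet been measured. It differs from compound 2 in one place: 4-chlorophenyl in place of ethoxy on a carbonyl carbon. Among the compounds with values here, no measured pair shows this exact change on the same core; the size of the step is therefore open. Compound 3 is expected to give 6.1, with a range from 5.3 to 6.9. The expected step of a number 0.03 log units higher from compound 2 to compound 3 (within the scatter) is small, none beyond the scatter.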

Compound 3, negative logarithm of the antagonist equilibrium constant: 5.23
Compound 3: the middle estimate sits 0.87 log units above what was measured; the whole stated range lies above it.
By their numbers in this assay, from the lowest: compounds 3 and 1 (each within the scatter of the next); then compound 2.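

On the shared core, the group on this carbonyl carbon matters: in this assay, 4-chlorophenyl in place of ethoxy gives a step of a number 0.84 log units lower from compound 2 to compound 3 (beyond the scatter) and so lowers potency. Within the data shown here, this is the first one-place comparison among the measured compounds, and here ethoxy is the better of the two groups. No available measurement explains the drop.

Still open, going by these compounds, is how a longer chain such as butoxy, an amine-derived amide or a carboxylic acid would fare on this carbonyl carbon. Whether the step holds on another core is also unknown.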